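A few compounds are considered here, and "the series" means these few. Any claim that something is new, unique, unknown or untested is made for them only; others in the source may bear on it.

Compound 1 `CCC(=O)c1ccc(OCCCCOc2ccc(F)c(C(=O)O)c2)c(C)c1O` reaches 66.6% in an assay on HEK293 cells for positive allosteric modulation of metabotropic glutamate receptor 2 (Rattus norvegicus), read by thallium flux, with a stated time of 2.5 min; on this read-out higher numbers stand for larger maximal responses and lower numbers for smaller maximal responses. Compound 2 `Cc1c(OCCCCOc2ccc(F)c(C(=O)O)c2)ccc(C(=O)C(C)C)c1O` reaches 74.1% in this assay; the step of a number 7.5 percentage points higher from compound 1 to compound 2 (within the scatter) belongs to the change (methyl in place of hydrogen on a saturated chain carbon bound to a carbonyl carbon and a saturated chain carbon). Compound 3 `COc1cc(C(=O)O)ccc1OCCCCOc1ccc(C(C)=O)c(O)c1C` reaches 86.3% in this assay, the highest of the three numbers; how its core differs from the core of compound 1 is not broken down here. Compound 4 `CCC(=O)c1ccc(OCCCCOc2ccc(C(=O)O)cc2OC)c(C)c1O` is not yet measured and differs from compound 3 by methyl in place of hydrogen on a saturated chain carbon bound to a carbonyl carbon. Going by the values given here, this is the same kind of change as the one made from compound 1 to compound 2, though around the place there the saturated chain carbon is also bound to a saturated chain carbon. Because the earlier step of a number 7.5 percentage points higher from compound 1 to compound 2 (within the scatter) stayed within the scatter, a similar small step a number 3.7 percentage points higher from compound 3 to compound 4 (within the scatter) is expected here. Compound 4 is therefore estimated at 90%, from 78% to 102%.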

Compound 4, largest response reached (reported as percent of maximum), in percent of the reference or control that the assay uses: 86.5%
For compound 4 the middle estimate is 3.5 percentage points above the measured one; measured number inside the range.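

On the second core, methyl in place of hydrogen on a saturated chain carbon bound to a carbonyl carbon, the acetyl to propanoyl change, gives a number 0.2 percentage points higher from compound 3 to compound 4 (within the scatter) in this assay. Set beside the first core, the change behaves alike within the scatter on both: the same change on two cores in this assay, a number 7.5 percentage points higher (within the scatter) from compound 1 to compound 2 and a number 0.2 percentage points higher (within the scatter) from compound 3 to compound 4, 7.3 percentage points apart, within the scatter of two such steps

This shows that the change can be carried between these two cores without a step that stands out from the scatter, but it does not show a real gain on either core, and two pairs set no rule for the series. From the compounds shown here alone, what a longer chain such as butanoyl, or an amide in place of the ketone, would give on these cores stays open, as does the size of the step on any other core.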